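Methoxy removal on the fused core: antiproliferative notes

This account rests on a few compounds, and the source may have more. Where it says the series, first, only, none or still open, it means among the compounds named here.

Measured compounds:
compound 1 `COc1cc(OC)c2sc(-c3ccc(N/C=C\C(=O)c4ccc(OC)c([N+](=O)[O-])c4)c(C)c3)nc2c1`, 12100 nM
compound 2 `COc1ccc(C(=O)/C=C\Nc2ccc(-c3nc4cc(OC)c(OC)c(OC)c4s3)cc2C)cc1[N+](=O)[O-]`, 9100 nM
compound 3 `COc1ccc(C(=O)/C=C\Nc2ccc(-c3nc4cc(OC)c(OC)c(OC)c4s3)cc2)cc1F`, 15500 nM

In a functional assay on A549 cells (Homo sapiens) for antiproliferative activity, read by sulforhodamine B assay, with a stated time of 48 h (on this read-out higher numbers stand for weaker inhibition and lower numbers for stronger inhibition), compound 2 gives 9100 nM and compound 1 gives 12100 nM. The step between them, a 1.3-fold higher number from compound 2 to compound 1 (0.12 log units; within the scatter), comes from the change (hydrogen in place of methoxy on an aromatic carbon). Compound 3 gives 15500 nM; how its core differs from the core of compound 2 is not broken down here, and the gap between the two values is within the scatter.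

Compound 4 `COc1cc(OC)c2sc(-c3ccc(N/C=C\C(=O)c4ccc(OC)c(F)c4)cc3)nc2c1` is not yet measured. It differs from compound 3 by hydrogen in place of methoxy on an aromatic carbon. The surroundings of the place are the same word for word as in the earlier pair, so this is the same change, made a second time in the series.

The expected step for compound 4 is a 1.2-fold higher number from compound 3 to compound 4 (0.09 log units; within the scatter). This rests on the earlier pair, because the same change gave a 1.3-fold higher number from compound 2 to compound 1 (0.12 log units; within the scatter), a step within the scatter. The estimate for compound 4 is 19000 nM, with a range from 9000 nM to 40000 nM.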

Compound 4, half-maximal inhibitory concentration: 5300 nM
Compound 4: the middle estimate sits 3.6-fold (0.55 log units) above what was measured, and the stated range ends above it.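

In this assay, hydrogen in place of methoxy on an aromatic carbon of the fused ring system gives a 2.9-fold lower number from compound 3 to compound 4 (0.47 log units; beyond the scatter), so on this core the change brings a modest gain rather than a result within the scatter. Among the compounds shown here, the change therefore does not carry from one core to another as a fixed step: the same change on two cores in this assay, a 1.3-fold higher number (0.12 log units; within the scatter) from compound 2 to compound 1 and a 2.9-fold lower number (0.47 log units; beyond the scatter) from compound 3 to compound 4, 3.9-fold (0.59 log units) apart, beyond the scatter of two such steps This shows that the step depends on the surrounding structure, but with only two pairs it does not show which difference between them, whether the fluorine or the nitro and methyl groups, sets the two steps apart, nor what a further core would give.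

Open, going by these compounds, is whether the step seen with compound 4 holds outside this assay. Also open, on these data alone, is what other replacements for methoxy at the same place would give, such as an ethoxy group, an amine or a carboxylic acid.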